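Methoxy to Nitro: Cytotoxicity Expected to Stay at the Limit

This account rests on a few compounds, and the source may have more. Where it says the series, first, only, none or still open, it means among the compounds named here.

Within the data shown here, in an ADME assay on MT4 cells (Homo sapiens) for cytotoxicity, read by MTT assay (on this read-out lower numbers stand for higher toxicity in this test and higher numbers for lower toxicity in this test), every value so far is a limit of the assay rather than a number. Compound 1 `Cc1c(Cc2ccccc2Br)nc(SCc2ccc([N+](=O)[O-])cc2)[nH]c1=O` gives >= 246000 nM, a limit. Compound 2 `Cc1c(Cc2cccc(Br)c2)nc(SCc2ccc([N+](=O)[O-])cc2)[nH]c1=O` gives > 280000 nM, also a limit. The step that the two limits leave unreadable from compound 1 to compound 2 therefore cannot be read. Compound 3 `COc1ccc(CSc2nc(Cc3cc(C)cc(C)c3)c(C)c(=O)[nH]2)cc1` gives > 329000 nM, again a limit. All three values thus sit at limits, namely (the limit of >= 246000 nM in this assay, at which 1 of the 3 values shown sits), the limit of > 280000 nM in this assay, at which 1 of the 3 values shown sits, and (the limit of > 329000 nM in this assay, at which 1 of the 3 values shown sits). Compound 4 `Cc1cc(C)cc(Cc2nc(SCc3ccc([N+](=O)[O-])cc3)[nH]c(=O)c2C)c1` differs from compound 3 by nitro in place of methoxy on an aromatic carbon. Among the measured compounds shown here, no measured step touches this change, and the only measured step was unreadable, so no shift beyond the scatter is expected. The step of an at least 1.0-fold lower number from compound 3 to compound 4 (0.04 log units; that floor lies within the scatter) is expected to be flat. Compound 4 is expected to give about 300000 nM, within 150000 nM to 600000 nM, most likely again as a limit.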

Compound 4, half-maximal cytotoxic concentration: > 316000 nM
Compound 4 gave a limit, no number (the forecaster's own chance of this, stated with the estimate: 85%); middle value at least 1.0-fold (0.02 log units) from the limit.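

Compound 4, like compound 1, compound 2 and compound 3, gives only a limit, so none of its steps to those compounds can be read. The compounds shown leave open whether nitro in place of methoxy changes cytotoxicity at all.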